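Swapping sec-butyl for a long amino chain

The compounds below may be only part of what the source reports. "The series", "measured", "known", "first", "only" and "open" are said of these compounds alone.

In a functional assay on PC-3 cells (Homo sapiens) for antiproliferative activity, read by WST assay, with a stated time of 3 days (a higher number here means a weaker inhibitor, a lower number a stronger inhibitor), compound 3 `CCC(C)Oc1c(-c2cc(OC)c(OC)c(OC)c2)oc2ccccc2c1=O`, which carries sec-butyl, gives 38600 nM. Compound 2 `COc1cc(-c2oc3ccccc3c(=O)c2OC(C)C)cc(OC)c1OC`, which carries isopropyl, gives 21200 nM, and a 1.8-fold higher number from compound 2 to compound 3 (0.26 log units; within the scatter) shows that these two cannot be told apart.

Compound 4 `CCN(CC)CCCCCOc1c(-c2cc(OC)c(OC)c(OC)c2)oc2ccccc2c1=O` has 5-(diethylamino)pentyl in place of sec-butyl on an oxygen on an aromatic ring. The new group is a long chain, so the closest measured comparison is compound 1 `CCCCCCCOc1c(-c2cc(OC)c(OC)c(OC)c2)oc2ccccc2c1=O`, which carries heptyl. Compound 1 gives > 50000 nM, which is a limit of the assay and not a number.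

Two measured steps start from that limit: an at least 2.3-fold lower number from compound 1 to compound 2 (0.37 log units; beyond the scatter) and an at least 1.2-fold lower number from compound 1 to compound 3 (0.11 log units; that floor lies within the scatter). Only the first clearly exceeds the scatter. Together they offer a warning that a long chain may go with weak activity, but it rests on compound 1 alone. Heptyl also contains no nitrogen, and neither does any other measured group, so these steps are only a loose guide to compound 4.

Weighing that warning against the untested nitrogen, the estimated change is a 1.9-fold lower number from compound 3 to compound 4 (0.29 log units; within the scatter), and no firm shift is expected. Compound 4 is expected to give about 20000 nM, with an estimated range of 5000 nM to 50000 nM.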

Compound 4, half-maximal inhibitory concentration: 6600 nM
Beside the measured number, compound 4's estimate is 3.0-fold (0.48 log units) above it; the measured number falls inside the stated range.
By their numbers in this assay, from the lowest: compound 4; then compounds 2 and 3 (each within the scatter of the next). At a limit, above all of these: compound 1.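

In this assay, the oxygen on the aromatic ring tolerates far more than small branched groups: 5-(diethylamino)pentyl gives a 5.8-fold lower number from compound 3 to compound 4 (0.77 log units; beyond the scatter) and a 3.2-fold lower number from compound 2 to compound 4 (0.51 log units; beyond the scatter), both beyond the scatter, which makes compound 4 the strongest inhibitor of the four. Chain length alone therefore does not bring weak activity, as the earlier heptyl comparison had hinted it might, for the chain that ends in diethylamino gives an at least 7.5-fold lower number from compound 1 to compound 4 (0.87 log units; beyond the scatter). That step is only a floor on the true size of the change, since compound 1 stands at a limit of the assay and not at a number: the limit of > 50000 nM in this assay, at which 1 of the 4 values shown sits.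

With a single amino chain among these compounds, the effect of the nitrogen cannot be separated from that of this particular chain length. A shorter chain ending in diethylamino, a pentyl chain ending in dimethylamino or piperidine, and a pentyl chain ending in a carboxylic acid would each test a different part of that question.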